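The source may report more compounds than this note shows. Statements on the series, on what has been measured and on what is new or still open speak of the compounds shown alone.

Compound 1 `Cc1cc(-c2ccc3[nH]c(=O)nc(-c4ccccc4)c3c2)ccn1` is one of three compounds tested in an ADME assay on L6 cells (Rattus norvegicus) for cytotoxicity, read by fluorescence and resazurin assay, with a stated time of 72 h; on this read-out lower numbers stand for an effect already at smaller amounts and higher numbers for an effect only at larger amounts of compound. In this assay compound 1 gives only a limit of the assay, > 50000 nM. Compound 3 `Cn1cc(-c2ccc3[nH]c(=O)nc(-c4ccccc4)c3c2)cn1` likewise gives only a limit, > 50000 nM. Compound 2 `O=c1nc(-c2ccccc2)c2cc(-c3ccc(F)cc3)ccc2[nH]1` gives 50000 nM. Among the measured compounds shown here, compound 1 thus stands at the limit of > 50000 nM in this assay, at which 2 of the 3 values shown sit, with no measured compound clearly apart from it. Compound 4 `CN1CCN(c2ccc3[nH]c(=O)nc(-c4ccccc4)c3c2)CC1` carries 4-methylpiperazin-1-yl in place of 2-methylpyridin-4-yl on an aromatic carbon. For the measured compounds named here, no measured step swaps this same pair of groups; the nearest comparisons are a number no higher from compound 1 to compound 2 (the limit leaves the size open) and a step that the two limits leave unreadable from compound 1 to compound 3, both left open by the limits. With every known value at or next to the limit, the step of a number no higher from compound 1 to compound 4 (the limit leaves the size open) is expected to stay within the usual scatter. Compound 4 is therefore estimated at 50000 nM, between 20000 nM and 100000 nM.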

Compound 4, half-maximal effective concentration: > 50000 nM
Compound 4 ended at the assay's limit (the forecaster's own chance of this, stated with the estimate: 65%); the middle value sits exactly at the limit.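

The earlier compounds carried only aromatic rings at this position, and 4-methylpiperazin-1-yl now places a non-aromatic ring there, yet the values in this assay stay together: the limit of > 50000 nM in this assay, at which 3 of the 4 values shown sit.

Against the one exact number, the result is a number no lower from compound 2 to compound 4 (the limit leaves the size open). The steps to compound 4 from compound 1 and from compound 3 cannot be read.

On these data alone, whether any group at this position brings the number clearly down from the limit stays open. A carboxylic acid or a primary amine on a longer chain is not among the compounds shown, so how either would read remains unknown.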